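Swapping the Aryl Amide Substituent: Methyl to Fluorine

The compounds below may be only part of what the source reports. "The series", "measured", "known", "first", "only" and "open" are said of these compounds alone.

Measured compounds:
compound 1 `Cc1c(C(=O)Nc2ccc(C(F)(F)F)cc2)cnn1Cc1ccc(F)cc1` gives 3600 nM
compound 2 `Cc1ccc(NC(=O)c2cnn(-c3ccc(F)cc3)c2C)cc1` gives 540 nM
compound 3 `Cc1c(C(=O)Nc2ccc(OC(F)(F)F)cc2)cnn1-c1ccc(F)cc1` gives 3400 nM

In a functional assay with Homo sapiens as the target (a lower number here means a stronger inhibitor, a higher number a weaker inhibitor), compound 2 gives the lowest number of the three, with compound 3 and compound 1 both higher by a margin beyond the usual scatter. The only single-point change among these three is the step of a 6.3-fold higher number from compound 2 to compound 3 (0.80 log units; beyond the scatter), where the ring attached to the amide-type nitrogen was altered, and the number rose clearly beyond the usual scatter. Compound 1 differs from compound 3 in more than one place, so its value can only be read on its own.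

Compound 4 `Cc1c(C(=O)Nc2cccc(F)c2)cnn1-c1ccc(F)cc1` is the next step from compound 2: 3-fluorophenyl in place of 4-methylphenyl on an amide-type nitrogen. This touches the same part of the molecule as the measured step, but swaps in a different substituent at a different point of the ring, so the earlier step is only a loose guide. Given that the one known change on this ring weakened inhibition, a moderate rise in the number is expected, a 2.2-fold higher number from compound 2 to compound 4 (0.35 log units; beyond the scatter), though a result within the scatter of compound 2 cannot be ruled out. The estimated value for compound 4 is 1200 nM, expected to fall between 400 nM and 4000 nM.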

Compound 4, half-maximal inhibitory concentration: 3000 nM
For compound 4 the middle estimate is 2.5-fold (0.40 log units) below the measured one; the range from low to high includes it.
By their numbers in this assay, from the lowest: compound 2; then compounds 4, 3 and 1 (each within the scatter of the next).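

In this assay, putting 3-fluorophenyl on the amide-type nitrogen gives a 5.6-fold higher number from compound 2 to compound 4 (0.74 log units; beyond the scatter) and so makes a weaker inhibitor, which means compound 3 is no longer the only replacement of 4-methylphenyl shown to lose activity. The count of heavy atoms does not separate this pair: 4-methylphenyl and 3-fluorophenyl each hold 7 heavy atoms and carry no hydrogen-bond donors or acceptors, yet the number still moves beyond the scatter. Compound 3 (3400 nM) and compound 4 (3000 nM) lie within the scatter of each other, so these two replacements cannot be ranked, while compound 2 (540 nM) keeps the lowest number.

This step removes the methyl, brings in a fluorine and changes the place of the substituent on the ring all at once, and the compounds shown do not tell these changes apart. Whether a longer chain or an amine on this ring could bring the number back toward that of compound 2 stays open, and no accompanying measurement explains the result.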